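The source may hold more compounds than are shown below. What is called first, only, known or untested is meant among the compounds shown, and "the series" means these compounds.

Working notes on a small set of analogues examined in an ADME assay on TZM cells (Homo sapiens) for cytotoxicity, read by CellTiter-Glo, with a stated time of 48 h; on this read-out lower numbers stand for higher toxicity in this test and higher numbers for lower toxicity in this test.

Compound 1 `COc1ccc(C2=Cc3ccc([N+](=O)[O-])cc3C(CC(C)=O)N2c2ccc(C#N)cc2)cc1` gives 15400 nM in this assay. Compound 2 `COc1ccc(C2=Cc3ccc([N+](=O)[O-])cc3C(CC(C)=O)N2c2ccc(O)cc2)cc1` carries the change hydroxy in place of cyano on an aromatic carbon relative to compound 1, and in this assay compound 2 gives 23500 nM. The step is a 1.5-fold higher number from compound 1 to compound 2 (0.18 log units; within the scatter), so the two numbers are not separated in any meaningful way.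

Compound 3 `COc1ccc(C2=Cc3ccc(F)cc3C(CC(=O)CO)N2c2ccc(C#N)cc2)cc1` rests on a different core from compound 1; how the two cores differ is not broken down here. In this assay compound 3 gives 39700 nM, the highest of the three numbers. Against compound 2 the gap is within the scatter, while against compound 1 it lies beyond it.

Compound 4 `COc1ccc(C2=Cc3ccc(F)cc3C(CC(=O)CO)N2c2ccc(O)cc2)cc1` is the not yet measured partner of compound 3 and carries the change (hydroxy in place of cyano on an aromatic carbon). Going by the values given here, the place of the change is described in the same words for both pairs, so this is the same change as the one from compound 1 to compound 2, made here on the core of compound 3. That earlier occurrence moved the number only within the scatter, and nothing in the shown data points to the change behaving differently on the second core. The expectation is therefore a step of about a 1.4-fold higher number from compound 3 to compound 4 (0.14 log units; within the scatter), resting on the step of a 1.5-fold higher number from compound 1 to compound 2 (0.18 log units; within the scatter) applied to the value of compound 3. Compound 4 is accordingly estimated at 55000 nM, with a plausible range from 30000 nM to 110000 nM, the upper end allowing for the possibility that the assay reports only a limit.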

Compound 4, half-maximal cytotoxic concentration: 47700 nM
Estimate against measurement, compound 4: 1.2-fold (0.06 log units) above, and the stated range covers the measured number.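

In this assay the replacement of cyano by hydroxy on an aromatic carbon gives a 1.2-fold higher number from compound 3 to compound 4 (0.08 log units; within the scatter), so this pair is not separated in any meaningful way. Set beside the earlier occurrence, the change reads alike on the two cores: the same change on two cores in this assay, a 1.5-fold higher number (0.18 log units; within the scatter) from compound 1 to compound 2 and a 1.2-fold higher number (0.08 log units; within the scatter) from compound 3 to compound 4, 1.3-fold (0.10 log units) apart, within the scatter of two such steps. This shows only that, on these two cores and in this one read-out, going from 4-cyanophenyl to 4-hydroxyphenyl leaves the number within the scatter both times; it does not show that the same would hold on a further core, and since neither step stands clear of the scatter, the two pairs give no measure of a real effect of the change on either core.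

The compounds shown leave open whether a different group at this place, such as an amine or a carboxylic acid, would stand apart from cyano and hydroxy in this assay. Going by these compounds alone, they also leave open what each difference between the two cores contributes, since the core of compound 1 and the core of compound 3 differ in more than one place and no pair here takes those differences one at a time.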